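The source may hold more compounds than are shown below. What is called first, only, known or untested is meant among the compounds shown, and "the series" means these compounds.

Working notes on the series

Three compounds of this set have been run in an assay on isolated protein for inhibition of Rho-associated protein kinase 2 (Homo sapiens), read by scintillation counting, radiometric assay and 33P incorporation, with a stated time of 40 min, in the presence of a further agent that is not named here (on this read-out higher numbers stand for weaker inhibition and lower numbers for stronger inhibition), and one more awaits measurement.

Compound 1 `Cc1cc(NC(=O)COc2ccc3c(=O)ccoc3c2)cc(NC(=O)c2ccc(N(C)C)cc2)c1` carries two methyl groups on its central ring. In this assay compound 1 gives only a limit of the assay, > 10000 nM. Compound 2 `Cc1cc(NC(=O)COc2ccc3c(=O)ccoc3c2)cc(NC(=O)c2ccc(N(C)C)cc2)c1C` differs from it in one place, described as methyl in place of hydrogen on an aromatic carbon. In this assay compound 2 gives 374 nM. Among the measured compounds shown here, the step of an at least 26-fold lower number from compound 1 to compound 2 (1.42 log units; beyond the scatter) is the one measured change in the set, and its size rests on (the limit of > 10000 nM in this assay, at which 1 of the 3 values shown sits), since the starting value is a limit rather than a number.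

Compound 3 `CN(C)c1ccc(C(=O)Nc2ccc(NC(=O)COc3ccc4c(=O)ccoc4c3)cc2)cc1` has a different arrangement of the central ring; the difference between the core of compound 3 and the core of compound 1 is not broken down here. In this assay compound 3 gives 302 nM. Against compound 2 this is a gap within the scatter, so no order between the two is claimed.

Compound 4 `Cc1cc(NC(=O)COc2ccc3c(=O)ccoc3c2)ccc1NC(=O)c1ccc(N(C)C)cc1` is not yet measured. It differs from compound 3 by methyl in place of hydrogen on an aromatic carbon. For the measured compounds named here, this is the same kind of change as the one from compound 1 to compound 2, but the surroundings differ: there the entering methyl sat ortho to a ((4-(dimethylamino)phenyl)carbonyl)amino group, ortho to a methyl group and para to a large group, whereas here it sits ortho to a large group and meta to a large group. Going by the values given here, with only one earlier example, and that one from a limit, no firm direction can be drawn from it.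

For compound 4 the expected step is a 1.0-fold lower number from compound 3 to compound 4 (0.00 log units; within the scatter), a modest change resting on compound 3 at 302 nM and on the one measured case of this kind of change. The estimate for compound 4 in this assay is 300 nM, with an expected range from 80 nM to 1500 nM.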

Compound 4, half-maximal inhibitory concentration: 4210 nM
Compound 4: the middle estimate sits 14-fold (1.15 log units) below what was measured; the measured number lies above the stated range.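

In this assay, methyl in place of hydrogen on an aromatic carbon, here ortho to a large group and meta to a large group, gives a 14-fold higher number from compound 3 to compound 4 (1.14 log units; beyond the scatter), so the gain in inhibition seen on the core of compound 1 does not carry over to the core of compound 3. Set side by side, the two steps run in opposite directions, and the gap between them is more than scatter can account for: the same change on two cores in this assay, an at least 26-fold lower number (1.42 log units; beyond the scatter) from compound 1 to compound 2 and a 14-fold higher number (1.14 log units; beyond the scatter) from compound 3 to compound 4, at least 370-fold (2.57 log units) apart, beyond the scatter of two such steps

The two cases show that the effect of this change cannot be taken from one core to the other in this series, but they do not show what sets its direction, whether the place of the methyl or the rest of the core, and the earlier step starts from a limit of the assay rather than a number: the limit of > 10000 nM in this assay, at which 1 of the 4 values shown sits.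

As far as these compounds go, it remains open whether a chlorine, a methoxy group or an ethyl group on the same aromatic carbon would follow the methyl of compound 4. Also open, from the compounds shown here alone, is whether the step keeps its direction and size when the dimethylamino group gives way to a pyrrolidine or a carboxylic acid.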